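The compounds below may be only part of what the source reports. "The series", "measured", "known", "first", "only" and "open" are said of these compounds alone.

Measured so far in a functional assay on Hep 3B2 cells (Homo sapiens) for antiproliferative activity, read by MTT assay, with a stated time of 24 h, tested at 0.14 ug/mL; a lower number here means a weaker effect, a higher number a stronger effect of the compound at the concentration tested:

- compound 1, `Cc1c(C(=O)Nc2c(F)cc(-c3cccc(F)c3)cc2F)nc2ccc(F)cc2c1O`: 2.65%
- compound 2, `CCc1ccc2nc(C(=O)Nc3c(F)cc(-c4cccc(F)c4)cc3F)c(C)c(C(=O)O)c2c1`: 0.68%

Compound 2 gives the lower of the two numbers in this assay, but its nearest neighbour, compound 1, sits within the usual scatter of it; the two readings cannot be told apart, and neither compound shows more than a marginal effect at the concentration tested.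

The next compound in the series, compound 3, `Cc1c(C(=O)Nc2c(F)cc(-c3cccc(F)c3)cc2F)nc2ccc(F)cc2c1C(=O)O`, is still to be measured in this assay. It is derived from compound 2 by a single change: fluoro in place of ethyl on an aromatic carbon

Among the compounds with values here, no step between two measured compounds has been recorded, so the size of this change cannot be read from any measured pair. Both readings so far lie close to the floor of the read-out, and the change concerns only the substituent on the fused carbocyclic ring, away from the amide and the biaryl part. The expectation is therefore a step of a number 0.8 percentage points higher from compound 2 to compound 3 (within the scatter) of no size beyond the scatter, in either direction. On that basis compound 3 is estimated at 1.5% in this assay, within a range from 0% to 8%.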

Compound 3, a percentage reported as inhibition, at one concentration (the size of the read-out at that concentration, not a potency): 0.65%
Beside the measured number, compound 3's estimate is 0.9 percentage points above it; low and high end bracket the measured number.
By their numbers in this assay, from the lowest: compounds 3, 2 and 1 (each within the scatter of the next).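

In this assay, within the data shown here, fluoro in place of ethyl on an aromatic carbon of the six-membered aromatic ring of carbon only gives a number 0 percentage points lower from compound 2 to compound 3 (within the scatter), the first reading of this position from a measured pair, and swapping a two-carbon chain for a single fluorine there leaves no step that can be told from the scatter. A second place can now be read as well: carboxy in place of hydroxy on an aromatic carbon gives a number 2 percentage points lower from compound 1 to compound 3 (within the scatter), so neither single change separates its pair in this read-out. Nothing measured bears on why these changes leave the reading where it is.

On these data alone, with every reading this close to the floor at a single concentration, it stays open whether either place matters at all under conditions where the effect is larger. Also open, as far as these compounds go, is how an amine, a methoxy group or a longer alkyl chain in place of ethyl, or an amide in place of carboxy, would read in this assay.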